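The compounds below may be only part of what the source reports. "The series", "measured", "known", "first", "only" and "open" are said of these compounds alone.

Among the measured compounds shown here, compound 2 `O=c1[nH]c2cc[nH]c2c(=O)n1CCN1CCN(c2ccccc2Cl)CC1` gives the lowest of the two plain numbers in an assay for binding affinity to Adrenergic receptor alpha-1 (Rattus norvegicus) (on this read-out higher numbers stand for weaker inhibition and lower numbers for stronger inhibition), namely 0.94 nM; compound 1 `COc1ccccc1N1CCN(CCn2c(=O)[nH]c3cc[nH]c3c2=O)CC1` gives 2.31 nM in this assay, and the single measured step, a 2.5-fold lower number from compound 1 to compound 2 (0.39 log units; beyond the scatter), concerns the far end of the molecule. Compound 3 `COc1ccc(N2CCN(CCn3c(=O)[nH]c4cc(-c5ccccc5)[nH]c4c3=O)CC2)cc1` gives only a limit in this assay, > 10000 nM. Compound 4 `Cc1ccc(-c2cc3[nH]c(=O)n(CCN4CCN(c5ccccc5Cl)CC4)c(=O)c3[nH]2)cc1` differs from compound 2 in one place: 4-methylphenyl in place of hydrogen on an aromatic carbon. For the measured compounds named here, no measured step touches this part of the shared core, so the measured steps offer no direct guide. Compound 3, which also carries an aryl ring on the five-membered ring of the core, sits at the limit of > 10000 nM in this assay, at which 1 of the 3 values shown sits. Compound 4 is therefore expected to show a large weakening, a 3200-fold higher number from compound 2 to compound 4 (3.50 log units; beyond the scatter), to an estimated 3000 nM (range 200 nM to 20000 nM).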

Compound 4, inhibition constant: 17.3 nM
Estimate against measurement, compound 4: 170-fold (2.24 log units) above, outside the stated range (below it).
By their numbers in this assay, from the lowest: compound 2; then compound 1; then compound 4. At a limit, above all of these: compound 3.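

In this assay, adding 4-methylphenyl on this aromatic carbon, next to the ring nitrogen, gives an 18-fold higher number from compound 2 to compound 4 (1.26 log units; beyond the scatter), so this position of the shared core does affect the read-out. The large step still leaves compound 4 with a measured number, 17.3 nM, showing that an aryl ring here need not drive the value out of measurable range. Compound 3 gives only a limit, and it differs from compound 4 in more than one place, so that limit cannot be pinned on its aryl ring alone: the limit of > 10000 nM in this assay, at which 1 of the 4 values shown sits.

Still open, on these data alone, is whether a plain methyl or an amine on this carbon would cost as much. It is also unclear whether the step depends on the methyl of the 4-methylphenyl ring.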